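The source may hold more compounds than are shown below. What is called first, only, known or untested is meant among the compounds shown, and "the series" means these compounds.

Compound 3 `COC(=O)c1ccc(OCCCCOc2ccc(C(=O)CC(C)C)c(O)c2C)cc1` carries a 4-(methoxycarbonyl)phenyl group on an oxygen on a saturated carbon, and in an assay on HEK293 cells for positive allosteric modulation of metabotropic glutamate receptor 3 (Rattus norvegicus), read by thallium flux, with a stated time of 2.5 min (a lower number here means that less compound is needed, a higher number that more compound is needed for the effect), compound 3 gives "not determined" (no result reported), so it stands nowhere on the measured scale; its position can only be inferred from its neighbours. Compound 1 `Cc1c(OCCCCOc2cccc(C(=O)O)c2)ccc(C(=O)CC(C)C)c1O` gives 1430 nM in this assay, and compound 2 `Cc1cc(C(=O)O)ccc1OCCCCOc1ccc(C(=O)CC(C)C)c(O)c1C` gives 1850 nM in this assay. Going by the values given here, the only measured step, a 1.3-fold higher number from compound 1 to compound 2 (0.11 log units; within the scatter), shows that exchanging 3-carboxyphenyl for 4-carboxy-2-methylphenyl leaves the number unchanged within the scatter.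

Compound 4 `Cc1ccc(C(=O)O)cc1OCCCCOc1ccc(C(=O)CC(C)C)c(O)c1C` differs from compound 3 as follows: 5-carboxy-2-methylphenyl in place of 4-(methoxycarbonyl)phenyl on an oxygen on a saturated carbon. The group that enters, 5-carboxy-2-methylphenyl, is a carboxylic acid variant of the same kind as those in compound 1 and compound 2, and the step from compound 1 to compound 2 suggests that moving the carboxy and methyl groups about this ring hardly changes the number in this assay. Among the compounds with values here, no measured step speaks to the ester of compound 3 itself. Compound 4 is therefore expected to sit near compound 1 and compound 2, with an estimated value of 1600 nM in this assay, in a range from 600 nM to 4500 nM.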

Compound 4, half-maximal effective concentration: > 10000 nM
Compound 4 gave a limit, no number; the forecaster's own chance of this, stated with the estimate: 10%; middle value at least 6.2-fold (0.79 log units) away from the limit.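

Compound 4 gives only a limit, not a number, in this assay: the limit of > 10000 nM in this assay, at which 1 of the 4 values shown sits.

This shows that the ring on this oxygen does not tolerate every arrangement of its carboxy and methyl groups: 5-carboxy-2-methylphenyl in place of 4-carboxy-2-methylphenyl gives an at least 5.4-fold higher number from compound 2 to compound 4 (0.73 log units; beyond the scatter), whereas the earlier exchange gave a 1.3-fold higher number from compound 1 to compound 2 (0.11 log units; within the scatter), which lies within the scatter. Methyl in place of hydrogen on an aromatic carbon gives an at least 6.9-fold higher number from compound 1 to compound 4 (0.84 log units; beyond the scatter), yet compound 2 also carries a methyl on this ring and stays within the scatter of compound 1, so among these three compounds neither the carboxy group nor the methyl group alone sets the outcome; the arrangement of the two does.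

Steps to compound 3 cannot be read, since it has no number, and the methyl ester therefore remains unplaced against the three acids. As far as these compounds go, it also remains open how a primary amide in place of the carboxylic acid, or a longer chain on the oxygen, would read in this assay.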